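Swapping a chlorophenyl for a pyridyl ring on the ketone

The source may hold more compounds than are shown below. What is called first, only, known or untested is meant among the compounds shown, and "the series" means these compounds.

Of the compounds shown here, three sharing one core have been measured in an assay on Sf21 cells for inhibition of cytochrome c oxidase subunit 2 (Homo sapiens), read by spectrophotometry, with a stated time of 5 min; a lower number here means a stronger inhibitor, a higher number a weaker inhibitor. Compound 1 `Cc1ccc(C(=O)CC2CC(=O)N(c3ccc(S(N)(=O)=O)cc3)C2=O)cc1` gives 980 nM. Compound 2 `NS(=O)(=O)c1ccc(N2C(=O)CC(CC(=O)c3ccccc3)C2=O)cc1` gives 4230 nM, and compound 3 `NS(=O)(=O)c1ccc(N2C(=O)CC(CC(=O)c3ccc(Cl)cc3)C2=O)cc1` gives 6290 nM. Compound 3 stands at the highest number of the three, though its gap to compound 2 is within the scatter, a 1.5-fold higher number from compound 2 to compound 3 (0.17 log units; within the scatter), while its gap to compound 1 is beyond it, a 6.4-fold higher number from compound 1 to compound 3 (0.81 log units; beyond the scatter). The step of a 4.3-fold higher number from compound 1 to compound 2 (0.64 log units; beyond the scatter) also lies beyond the scatter.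

Compound 4 `NS(=O)(=O)c1ccc(N2C(=O)CC(CC(=O)c3ccccn3)C2=O)cc1` has not yet been measured. Its difference from compound 3 is pyridin-2-yl in place of 4-chlorophenyl on a carbonyl carbon. Going by the values given here, no measured step exchanges a carbon ring for a ring containing nitrogen, so none bears directly on this change. The nearest guide is that removing the chloro, as in the step from compound 3 to compound 2, stayed within the scatter, and compound 2 carries an unsubstituted ring on the same carbonyl. The expected step of a 1.4-fold lower number from compound 3 to compound 4 (0.15 log units; within the scatter) in this assay is therefore small, without a clear direction. For compound 4 the estimate in this assay is 4500 nM, with a range from 1500 nM to 13000 nM.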

Compound 4, half-maximal inhibitory concentration: 8940 nM
The estimate for compound 4 lay 2.0-fold (0.30 log units) below the measured number; low and high end bracket the measured number.
By their numbers in this assay, from the lowest: compound 1; then compounds 2, 3 and 4 (each within the scatter of the next, the first and the last beyond it).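

In this assay, exchanging 4-chlorophenyl for pyridin-2-yl on the carbonyl carbon gives a 1.4-fold higher number from compound 3 to compound 4 (0.15 log units; within the scatter), so a ring containing nitrogen cannot be told apart from the chlorinated carbon ring at this position. Measured against the unsubstituted ring, the same exchange gives a 2.1-fold higher number from compound 2 to compound 4 (0.32 log units; beyond the scatter), a step only just past the usual scatter, while against the 4-methylphenyl ring it gives a 9.1-fold higher number from compound 1 to compound 4 (0.96 log units; beyond the scatter), the largest step among these compounds. Compound 1 is now the only compound whose steps to all the others lie beyond the scatter, so the 4-methylphenyl ring alone stands apart in this set, and no measurement shown explains that or any of the other steps.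

Whether pyridin-3-yl or pyridin-4-yl on the same carbonyl carbon would read like pyridin-2-yl stays open, so the compounds shown cannot say whether the place of the nitrogen in the ring matters. Also open, as far as these compounds go, is whether the lower number of compound 1 is specific to its methyl, a question that an ethyl or methoxy group standing in place of that methyl could help to answer.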